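The compounds below may be only part of what the source reports. "The series", "measured", "known", "first", "only" and "open" are said of these compounds alone.

Working notes on the series. Of the compounds shown here, two of the shared core have been measured in a functional assay on A549 cells (Homo sapiens) for cytotoxicity, read by MTT assay, with a stated time of 24 h; on this read-out higher numbers stand for weaker inhibition and lower numbers for stronger inhibition. Compound 1, `FC(F)(F)C(F)(F)C(F)(F)C(F)(F)C(F)(F)C(F)(F)C(F)(F)C(F)(F)CCn1cc(COc2ccccc2-c2nc3ccccc3s2)nn1`, gives 13100 nM in this assay. Compound 2, `Fc1ccccc1-c1cc(COc2ccccc2-c2nc3ccccc3s2)on1`, gives 22500 nM in this assay; this is the higher of the two numbers, but the gap to compound 1 lies within the scatter, so the two cannot be ordered.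

The next compound, compound 3, `Cc1ccc(-c2cc(COc3ccccc3-c3nc4ccccc4s3)on2)cc1`, is not yet measured. It differs from compound 2 in one place: 4-methylphenyl in place of 2-fluorophenyl on an aromatic carbon. Within the data shown here, no measured pair shows this change or anything close to it, so there is no step to lean on. On the numbers at hand the expectation is no step beyond the scatter in either direction. The step from compound 2 to compound 3 in this assay is estimated as a 1.1-fold lower number from compound 2 to compound 3 (0.05 log units; within the scatter). Compound 3 is expected to give about 20000 nM in this assay. The estimated range for compound 3 runs from 8000 nM to 50000 nM.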

Compound 3, half-maximal inhibitory concentration: 16400 nM
Beside the measured number, compound 3's estimate is 1.2-fold (0.09 log units) above it; measured number inside the range.
By their numbers in this assay, from the lowest: compounds 1, 3 and 2 (each within the scatter of the next).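

Among these compounds, compound 2 and compound 3 form the first pair that differs in one place: on an aromatic carbon of the five-membered aromatic ring with one nitrogen and one oxygen, 4-methylphenyl in place of 2-fluorophenyl is a 1.4-fold lower number from compound 2 to compound 3 (0.14 log units; within the scatter) in this assay. This read-out therefore does not separate these two substituted phenyl groups at this position, and since both groups carry the same count of heavy atoms, the pair says nothing about a larger or smaller group there. Nothing at hand gives a measured property that bears on this result.

Still open, from the compounds shown here alone, is whether an unsubstituted phenyl, an amine or a carboxylic acid at this position would give a step beyond the scatter. The pair also leaves open how the fluorine and the methyl group each contribute, as the two groups differ in both substituent and ring position.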